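A Larger Alkyl Tail on the Urea of Compound 2

This account rests on a few compounds, and the source may have more. Where it says the series, first, only, none or still open, it means among the compounds named here.

Compound 1, `CC(C)c1ccccc1OS(=O)(=O)c1ccc(NC(=O)CCCCl)cc1`, gives 5100 nM in a functional assay on M21 cells (Homo sapiens) for antiproliferative activity, read by sulforhodamine B assay, with a stated time of 48 h; on this read-out higher numbers stand for weaker inhibition and lower numbers for stronger inhibition.
Compound 2, `CCNC(=O)Nc1ccc(S(=O)(=O)Oc2ccccc2C(C)C)cc1`, gives 4700 nM in this assay.

Compound 2 holds the lowest of the two numbers shown, with compound 1 nearest, and the step of a 1.1-fold lower number from compound 1 to compound 2 (0.04 log units; within the scatter) lies within the scatter. Compound 3, `CC(C)c1ccccc1OS(=O)(=O)c1ccc(NC(=O)NCC2CCCC2)cc1`, differs from compound 2 by cyclopentyl in place of methyl on a saturated chain carbon bound to an amide-type nitrogen. Among the measured compounds shown here, the one measured step changes a different part of the molecule, so it gives no guide to the size of this alteration. Compound 3 is therefore expected to stay close to compound 2, with an estimated step of a 1.3-fold lower number from compound 2 to compound 3 (0.13 log units; within the scatter). The estimate for compound 3 is 3500 nM, within a range of 1200 nM to 10000 nM.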

Compound 3, half-maximal inhibitory concentration: 6600 nM
Estimate against measurement, compound 3: 1.9-fold (0.28 log units) below; the range from low to high includes it.
By their numbers in this assay, from the lowest: compounds 2, 1 and 3 (each within the scatter of the next).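

Placing cyclopentyl where the ethyl tail of compound 2 ends in methyl brings in a five-membered carbon ring, yet this assay gives a 1.4-fold higher number from compound 2 to compound 3 (0.15 log units; within the scatter) and no change that can be read. The comparison with the 3-chloropropyl amide agrees, with a 1.3-fold higher number from compound 1 to compound 3 (0.11 log units; within the scatter) for the swap to (cyclopentylmethyl)amino on the carbonyl carbon. So this position accepts a much larger carbon group without a clear shift in the number, and no measurement at hand bears on why.

On these data alone, whether an amine, a carboxylic acid or a phenyl ring on this chain would move the number beyond the scatter remains open.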